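A few compounds are considered here, and "the series" means these few. Any claim that something is new, unique, unknown or untested is made for them only; others in the source may bear on it.

Of the compounds shown here, three sharing one core have been measured so far, each carrying a different acyl chain on the amide nitrogen. Compound 1 `CC(C)C(=O)Nc1c(C(O)(C(F)(F)F)C(F)(F)F)ccc2ccccc12` bears an isopropyl group on the carbonyl carbon and gives 6630 nM in an assay on LtK cells with ATP-sensitive inward rectifier potassium channel 11 (Homo sapiens) as the target; on this read-out lower numbers stand for an effect already at smaller amounts and higher numbers for an effect only at larger amounts of compound. Compound 2 `CCCC(=O)Nc1c(C(O)(C(F)(F)F)C(F)(F)F)ccc2ccccc12`, with a propyl group in the same place, gives 131 nM. Compound 3 `CCC(CC)C(=O)Nc1c(C(O)(C(F)(F)F)C(F)(F)F)ccc2ccccc12`, with a pentan-3-yl group there, gives 4340 nM; it stands second highest of the three numbers, close to compound 1 and far from compound 2.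

Compound 4 `CC(C)=CC(=O)Nc1c(C(O)(C(F)(F)F)C(F)(F)F)ccc2ccccc12` has not yet been measured. It differs from compound 3 in one place: 2-methylprop-1-en-1-yl in place of pentan-3-yl on a carbonyl carbon. The new group is unbranched at the carbon joined to the carbonyl, like the propyl of compound 2, whereas isopropyl and pentan-3-yl are branched there.

Within the data shown here, two measured steps bear on this. The step of a 51-fold lower number from compound 1 to compound 2 (1.70 log units; beyond the scatter) shows how much the unbranched propyl chain gains over the branched isopropyl, and the step of a 33-fold higher number from compound 2 to compound 3 (1.52 log units; beyond the scatter) shows the same gap in the other direction; the step of a 1.5-fold lower number from compound 1 to compound 3 (0.18 log units; within the scatter) shows that the two branched chains sit together. Among the measured compounds shown here, since compound 4 returns to an unbranched chain, a large drop in number is expected, though the new double bond has no measured counterpart. The estimated step is an 11-fold lower number from compound 3 to compound 4 (1.04 log units; beyond the scatter), and compound 4 is expected to give 400 nM, with a range from 80 nM to 2500 nM.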

Compound 4, half-maximal effective concentration: 46 nM
Compound 4: middle estimate off by 8.7-fold (0.94 log units), on the high side; measured number below the stated range.
By their numbers in this assay, from the lowest: compound 4; then compound 2; then compounds 3 and 1 (each within the scatter of the next).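

In this assay the change to 2-methylprop-1-en-1-yl on the carbonyl carbon gives a 94-fold lower number from compound 3 to compound 4 (1.97 log units; beyond the scatter) against pentan-3-yl and a 140-fold lower number from compound 1 to compound 4 (2.16 log units; beyond the scatter) against isopropyl, so compound 4 stands far from both of these compounds. Among these compounds, the earlier compounds showed propyl alone giving a low number at this position, but the step of a 2.8-fold lower number from compound 2 to compound 4 (0.45 log units; beyond the scatter) is modest yet beyond the scatter and makes compound 4 the lowest of the four, so propyl is not the only group that does well here, and a group with a double bond outside the aromatic rings is accepted. No measurement among those shown explains what this group adds at this position.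

On these data alone, whether the gain comes from the double bond or from the shape of the chain stays open, and the saturated 2-methylpropyl group on the same carbonyl carbon would separate the two. As far as these compounds go, how far the trend reaches is also open, as a butyl chain, a cyclopropyl ring or an amine-bearing chain could each land well above or below the numbers seen so far.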